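Swapping trifluoromethyl for methoxy on a second core

This account rests on a few compounds, and the source may have more. Where it says the series, first, only, none or still open, it means among the compounds named here.

Four compounds share a common theme: a benzimidazole-type core carrying an aryl ring that bears either trifluoromethyl or methoxy. Compound 1 is `C/C(=N\NC(N)=S)c1ccc2[nH]c(-c3ccc(C(F)(F)F)cc3)nc2c1` and compound 2 is `COc1ccc(-c2nc3cc(/C(C)=N/NC(N)=S)ccc3[nH]2)cc1`. Compound 3 is `CC(=O)c1ccc2c(c1)nc(-c1ccc(C(F)(F)F)cc1)n2C1CCCCC1`, and compound 4, not yet measured, is `COc1ccc(-c2nc3cc(C(C)=O)ccc3n2C2CCCCC2)cc1`.

The measurements come from an ADME assay on MDBK cells (Bos taurus) for cytotoxicity, read by MTT assay, with a stated time of 96 h; a lower number here means that less compound is tolerated, a higher number that more compound is tolerated. In this assay compound 1 gives 5000 nM, and compound 2 gives 13000 nM. The change between them is methoxy in place of trifluoromethyl on an aromatic carbon, and the effect is a 2.6-fold higher number from compound 1 to compound 2 (0.41 log units; beyond the scatter), so more of compound 2 was tolerated by the cells than of compound 1.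

Compound 3 stands on a different core; the difference between the two cores is not broken down here. In this assay compound 3 gives 52000 nM, the highest of the three measured numbers and beyond the scatter from both compound 1 and compound 2.

The change from compound 3 to compound 4 is methoxy in place of trifluoromethyl on an aromatic carbon, the same change as from compound 1 to compound 2, in the same place. If that earlier step carries over, compound 4 is expected to be tolerated still better than compound 3, with an expected step of a 2.1-fold higher number from compound 3 to compound 4 (0.33 log units; beyond the scatter), resting on the step from compound 1 to compound 2 of a 2.6-fold higher number from compound 1 to compound 2 (0.41 log units; beyond the scatter). The estimate for compound 4 in this assay is 110000 nM, with a range expected from 50000 nM to 250000 nM.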

Compound 4, half-maximal cytotoxic concentration: > 100000 nM
Compound 4: a limit, no number (the forecaster's own chance of this, stated with the estimate: 35%); the middle value does not contradict the limit.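

In this assay compound 4 gives > 100000 nM, which is a limit of the assay and not a number. Methoxy in place of trifluoromethyl gives an at least 1.9-fold higher number from compound 3 to compound 4 (0.28 log units; that floor lies within the scatter), so the result fits a rise on this second core as well, but the floor alone does not establish one, and the real step could be small or much larger. The result therefore shows no conflict with carrying the change from the core of compound 1 to the core of compound 3, yet it does not show that the step has the same size on both: the same change on two cores in this assay, a 2.6-fold higher number (0.41 log units; beyond the scatter) from compound 1 to compound 2 and an at least 1.9-fold higher number (0.28 log units; that floor lies within the scatter) from compound 3 to compound 4; the limit leaves it open whether they differ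

The compounds shown leave open how large the step on the second core really is, and whether the same pattern would appear on any further core. They also leave open what other groups would do on that aromatic carbon, such as an amine or a carboxylic acid in place of methoxy or trifluoromethyl.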